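Amino for hydroxy on the diaryl ketone series

The compounds below may be only part of what the source reports. "The series", "measured", "known", "first", "only" and "open" are said of these compounds alone.

Compound 1 `COc1ccc(C(=O)c2ccc(OC)c(O)c2OC)cc1` carries a hydroxy group on its ketone-bearing ring, but in a functional assay on A549 cells (Homo sapiens) for cytotoxicity, read by sulforhodamine B assay, with a stated time of 48 h (on this read-out lower numbers stand for stronger inhibition of growth and higher numbers for weaker inhibition of growth), compound 1 gives "not determined" (no result reported), so it contributes no number to the series. For the measured compounds named here, compound 2 `COc1ccc(C(=O)c2cc(OC)c(OC)c(OC)c2)c(OC)c1O` is the only compound with a value: in this assay compound 2 gives 41.3 nM, which therefore stands alone as the reference point, with no step between measured compounds available.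

Compound 3 `COc1ccc(C(=O)c2cc(OC)c(OC)c(OC)c2)c(OC)c1N` differs from compound 2 in one place: amino in place of hydroxy on an aromatic carbon. The group that leaves and the group that enters each bring one heavy atom, one hydrogen-bond donor and one hydrogen-bond acceptor, on an aromatic carbon ortho to two methoxy groups and meta to a large group.

Going by the values given here, with only one measured value and no measured step to lean on, the expectation is that the step from compound 2 to compound 3 in this assay stays within the usual scatter, or at most a modest shift in either direction, a 1.2-fold higher number from compound 2 to compound 3 (0.08 log units; within the scatter). Compound 3 is accordingly estimated at 50 nM, with a range from 15 nM to 160 nM.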

Compound 3, concentration for 50% growth inhibition: 39 nM
Compound 3: the middle estimate sits 1.3-fold (0.11 log units) above what was measured; the range from low to high includes it.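

In this assay, for the compounds shown here, the exchange of hydroxy for amino gives a 1.1-fold lower number from compound 2 to compound 3 (0.02 log units; within the scatter) and is the first measured step. At this aromatic carbon, ortho to two methoxy groups and meta to a large group, the two groups cannot be told apart on this read-out, so for this pair the growth-inhibition value does not depend on having hydroxy rather than amino there. Nothing available on these compounds accounts for the two groups reading alike, and this single pair supports no wider rule about the position or the change.

Still open, as far as these compounds go, is whether the value holds with other groups on the same carbon, such as a hydrogen, a fluorine, a methylamino group or an acetamide, which would show whether any group is tolerated there or only hydroxy and amino. From the compounds shown here alone, it is also open whether amino for hydroxy reads the same on another scaffold, as compound 1 gives "not determined" (no result reported) and differs from compound 2 and compound 3 in more than one place.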